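Compound 1 to compound 4: a benzyl step

A few compounds are considered here, and "the series" means these few. Any claim that something is new, unique, unknown or untested is made for them only; others in the source may bear on it.

In a physicochemical assay for lipophilicity, at pH 7.4 (a lower number here means a more polar compound, a higher number a more lipophilic compound), compound 1 (`COc1ccc2c(=O)cc(C)[nH]c2c1`) gives 1.2 and is the lowest of the three measured compounds. Compound 2 (`CCCCCCCc1c(C)nc2ccccc2c1O`) stands at 3.39 and compound 3 (`CCCCC#Cc1c(C)[nH]c2ccccc2c1=O`) at 5.44 on the same scale. Both lie beyond the scatter above compound 1.

Compound 4 (`COc1ccc2c(=O)c(Cc3ccccc3)c(C)[nH]c2c1`) keeps the core of compound 1 and carries a single change (benzyl in place of hydrogen on an aromatic carbon): benzyl in place of hydrogen on an aromatic carbon, ortho to a methyl group and two atoms from the ring nitrogen.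

Among the compounds with values here, no two measured compounds differ in only one place, so the series gives no direct measure of this step. The guide is indirect and weak. Compound 2 at 3.39 and compound 3 at 5.44 each carry a side chain of carbon that compound 1 lacks, though both also differ from compound 1 elsewhere. A rise beyond the scatter in this assay is therefore expected, with compound 4 landing nearer compound 2 than compound 3. The estimated change is a number 1.80 log units higher from compound 1 to compound 4 (beyond the scatter) and is expected to be upward. For compound 4 the estimated value is 3 with an expected range from 2.3 to 3.7 in this measurement.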

Compound 4, distribution coefficient: 2.52
The estimate for compound 4 lay 0.48 log units above the measured number; measured number inside the range.
By their numbers in this assay, from the lowest: compound 1; then compound 4; then compound 2; then compound 3.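

Benzyl in place of hydrogen on an aromatic carbon, ortho to a methyl group and two atoms from the ring nitrogen, gives the first single-place reading in the series: in this assay the step is a number 1.32 log units higher from compound 1 to compound 4 (beyond the scatter) and it is the only direct measure of a change at this carbon. The rest of the core of compound 1 stays fixed across this step, and the entering group brings 0 hydrogen-bond donors, 0 hydrogen-bond acceptors and no net charge, so the reading belongs to this one exchange at this one position. No measurement available here bears on why the step has this size.

Open, going by these compounds, is how the reading changes with an ethyl or a longer chain at this carbon in place of benzyl, or with a carboxylic acid or an amine on the benzyl ring. Also open, on these data alone, is whether benzyl at the same place gives a step of similar size on a core other than that of compound 1, since one step fixes neither a trend nor its generality.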